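Cytotoxicity of Compound 4 Expected Near Compound 2

This account rests on a few compounds, and the source may have more. Where it says the series, first, only, none or still open, it means among the compounds named here.

Of the compounds shown here, three have been tested in a toxicity assay on NIH3T3 cells (Mus musculus) for cytotoxicity, read by resazurin assay; a higher number here means that more compound is needed for the effect, a lower number that less compound is needed. Compound 1 `CN(C)c1ccc(NCc2cncn2Cc2ccc(-c3ccccc3)cc2)cc1-c1ccccc1` gives > 1000 nM, which is a limit of the assay rather than a number. Compound 3 `c1ccc(-c2ccc(Cn3cncc3CNc3ccc(-c4cc5ccccc5o4)c(-c4ccccc4)c3)cc2)cc1` gives > 10000 nM, again a limit. The step between these two, a step that the two limits leave unreadable from compound 1 to compound 3, is therefore not readable. Within the data shown here, compound 2 `COC(=O)c1ccc(NCc2cncn2Cc2ccccc2Br)cc1-c1ccccc1` is the only compound with a number, at 10000 nM. Compound 4 `COC(=O)c1ccc(NCc2cncn2Cc2ccc(C#N)cc2)cc1-c1ccccc1` is not yet measured; it differs from compound 2 by 4-cyanophenyl in place of 2-bromophenyl on a saturated chain carbon bound to an aromatic nitrogen. Among the measured compounds shown here, no measured step involves this change, and the single measured step is unreadable, so nothing points to a move beyond the scatter in this assay. The step expected is no change at the digits printed from compound 2 to compound 4 (within the scatter). Compound 4 is thus expected at 10000 nM, within 3000 nM to 30000 nM.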

Compound 4, half-maximal effective concentration: > 10000 nM
Compound 4 gave a limit, no number; the forecaster's own chance of this, stated with the estimate: 40%; the middle value lies on the limit itself.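

In this assay, among these compounds, this is the first view of a change on the saturated chain carbon bound to an aromatic nitrogen, and 2-bromobenzyl to 4-cyanobenzyl gives a number no lower from compound 2 to compound 4 (the limit leaves the size open). Among the compounds shown here, the change therefore brings no sign that less compound is needed for the effect. The value of compound 4 is a limit, not a number: the limit of > 10000 nM in this assay, at which 2 of the 4 values shown sit.

As far as these compounds go, how far compound 4 lies from compound 2 stays open. So does whether a benzyl carrying an amine at this place would give a readable number in this assay.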